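From compound 2 to compound 4: an amide swap

The source may hold more compounds than are shown below. What is called first, only, known or untested is meant among the compounds shown, and "the series" means these compounds.

Of the compounds shown here, three have been measured so far in a functional assay on KB cells (Homo sapiens) for cytotoxicity, read by MTT assay (a higher number here means a weaker inhibitor, a lower number a stronger inhibitor), on the read-out of half-maximal inhibitory concentration. Compound 1 `CCn1cc(-c2nc3ccc([N+](=O)[O-])cc3o2)c(=O)c2cc(F)c(N3CCNC(C)C3)c(F)c21` comes in at 900 nM and compound 2 `CCn1cc(C(=O)Nc2cccc([N+](=O)[O-])c2)c(=O)c2cc(F)c(N3CCNC(C)C3)c(F)c21` at 1700 nM while compound 3 `CCn1cc(C(=O)Nc2ccc(OC)cc2)c(=O)c2cc(F)c(N3CCNC(C)C3)c(F)c21` gives 2600 nM on the same scale. Compound 2 holds the middle of these three numbers, and its gaps to compound 1 and compound 3 both lie within the usual scatter of repeated measurements.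

Compound 4 `CCn1cc(C(=O)Nc2ccc(OC(F)(F)F)cc2)c(=O)c2cc(F)c(N3CCNC(C)C3)c(F)c21` has not yet been measured. It carries 4-(trifluoromethoxy)phenyl in place of 3-nitrophenyl on an amide-type nitrogen. Among the compounds with values here, the one measured step at this place is a 1.5-fold higher number from compound 2 to compound 3 (0.18 log units; within the scatter) with 4-methoxyphenyl taking the place of 3-nitrophenyl. Within the data shown here, a single step is thin evidence, and no measured compound carries 4-(trifluoromethoxy)phenyl. Among the measured compounds shown here, with that small step as the only guide, no change beyond the scatter is expected in this assay for this swap. The expected size is modest, with a 1.4-fold higher number from compound 2 to compound 4 (0.13 log units; within the scatter) as the estimate. For compound 4 the estimated value is 2300 nM (expected range 1000 nM to 5000 nM).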

Compound 4, half-maximal inhibitory concentration: 1400 nM
Beside the measured number, compound 4's estimate is 1.6-fold (0.22 log units) above it; the measured number falls inside the stated range.
By their numbers in this assay, from the lowest: compounds 1, 4, 2 and 3 (each within the scatter of the next, the first and the last beyond it).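

Placing 4-(trifluoromethoxy)phenyl on the amide-type nitrogen in place of 3-nitrophenyl gives a 1.2-fold lower number from compound 2 to compound 4 (0.08 log units; within the scatter) in this assay, so a second replacement at this place also stays inside the noise of the measurement. Trifluoromethyl in place of methyl on the oxygen gives a 1.9-fold lower number from compound 3 to compound 4 (0.27 log units; within the scatter) and is the first comparison that changes only the end of the group on the ring, yet it too cannot be told apart from repeat measurements. Compounds 2, 3 and 4 therefore read alike in this assay whichever of these three groups they carry, and no other measurement is available that would help to interpret this.

The compounds shown leave open whether an amine or a carboxylic acid on the phenyl ring, or a plain alkyl chain in place of the ring, would move the number beyond the scatter. As far as these compounds go, whether the amide hydrogen matters also remains open, and a methyl group on that nitrogen would be one way to test it.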